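The compounds below may be only part of what the source reports. "The series", "measured", "known", "first", "only" and "open" are said of these compounds alone.

Measured compounds in a functional assay on PC-3 cells (Homo sapiens) for cytotoxicity, read by MTT assay, with a stated time of 72 h; a higher number here means a weaker inhibitor, a lower number a stronger inhibitor:
- compound 1, `Cc1ccc(S(=O)(=O)n2cc(COC3=C/C(=N\c4ccc(Br)cc4)c4ccccc4C3=O)nn2)cc1`: 3410 nM
- compound 2, `Cc1ccc(S(=O)(=O)n2cc(COC3=C/C(=N\c4ccc(F)cc4)c4ccccc4C3=O)nn2)cc1`: 2030 nM

Compound 2 holds the lowest of the two numbers in this assay, but its nearest neighbour is compound 1, and the step of a 1.7-fold lower number from compound 1 to compound 2 (0.23 log units; within the scatter) lies within the scatter, so no order between the two can be read from it.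

Compound 3, `Cc1ccc(S(=O)(=O)n2cc(COC3=C/C(=N\c4ccc(Cl)cc4)c4ccccc4C3=O)nn2)cc1`, has not yet been measured in this assay. It differs from compound 2 as follows: chloro in place of fluoro on an aromatic carbon. Among the measured compounds shown here, the only step that bears on this change is the one between compound 1 and compound 2, where bromo was replaced by fluoro at the same place: a 1.7-fold lower number from compound 1 to compound 2 (0.23 log units; within the scatter). Since that step was within the scatter, no movement beyond the scatter is expected for the step of a 1.3-fold higher number from compound 2 to compound 3 (0.11 log units; within the scatter); the number for compound 3 is expected near those of both neighbours.

Compound 3 is therefore estimated at 2600 nM in this assay, with a range of 1200 nM to 5500 nM.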

Compound 3, half-maximal inhibitory concentration: > 20000 nM
Compound 3 gave a limit, no number (the forecaster's own chance of this, stated with the estimate: 5%); at least 7.6-fold (0.88 log units) between middle value and limit.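

Compound 3 gives a limit, not a number, in this assay: the limit of > 20000 nM in this assay, at which 1 of the 3 values shown sits. The earlier exchange of bromo for fluoro at this place, on an aromatic carbon para to a large group, stayed within the scatter and suggested a position indifferent to the choice of halogen, but chloro breaks that picture, with an at least 9.8-fold higher number from compound 2 to compound 3 (0.99 log units; beyond the scatter) and an at least 5.8-fold higher number from compound 1 to compound 3 (0.76 log units; beyond the scatter). The result at this place therefore does not follow the row fluoro, chloro, bromo, since chloro stands apart from both of the groups on either side of it in that row.

Going by these compounds, the true size of both new steps stays open, as the limit fixes only their lower bound. Also open, on these data alone, is whether a methoxy group, an amine or a nitrile at this place would read like compound 3 or like compound 1 and compound 2.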